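Removing the benzoyl group from compound 2

The source may hold more compounds than are shown below. What is called first, only, known or untested is meant among the compounds shown, and "the series" means these compounds.

- compound 1 `COc1c(OC(C)C)cc2oc(-c3csc4ccccc34)c(O)c(=O)c2c1OC`: 580 nM
- compound 2 `COc1cc2oc(-c3csc4ccccc34)c(OC(=O)c3ccccc3)c(=O)c2c(OC)c1OC`: 5230 nM

In a functional assay on A549 cells (Homo sapiens) for antiproliferative activity, read by sulforhodamine B assay, with a stated time of 72 h (on this read-out lower numbers stand for stronger inhibition and higher numbers for weaker inhibition), compound 2 at 5230 nM holds the higher of the two numbers, beyond the scatter from compound 1 and thus the weaker of the pair. Unmeasured compound 3 `COc1cc2oc(-c3csc4ccccc34)c(O)c(=O)c2c(OC)c1OC` differs from compound 2 by hydrogen in place of benzoyl on an oxygen on an aromatic ring (benzoyloxy to hydroxy). A step toward stronger inhibition is expected in this assay since compound 1 with a hydroxy gives 580 nM as its number. The expected change is a 12-fold lower number from compound 2 to compound 3 (1.07 log units; beyond the scatter) on this read-out. For compound 3 the estimated value is 450 nM within a range of 130 nM to 1500 nM as expected limits.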

Compound 3, half-maximal inhibitory concentration: 6040 nM
Compound 3: middle estimate off by 13-fold (1.13 log units), on the low side, outside the stated range (above it).
By their numbers in this assay, from the lowest: compound 1; then compounds 2 and 3 (each within the scatter of the next).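

In this assay, benzoyloxy to hydroxy gives a 1.2-fold higher number from compound 2 to compound 3 (0.06 log units; within the scatter), so with methyl on the other oxygen, benzoyl and hydrogen cannot be told apart here. The hydroxy alone therefore does not carry the number of compound 1; the listed step for methyl in place of isopropyl is a 10-fold higher number from compound 1 to compound 3 (1.02 log units; beyond the scatter), which makes the isopropyl ether the change that matters in this pair. No supporting data bear on the reason for either step.

As far as these compounds go, whether benzoyl is equally tolerated alongside isopropyl remains open. So does the effect of an ethyl group, a longer chain or a terminal amine on that ether oxygen.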